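Replacing the 4-chlorophenyl on sulfur in compound 2

The source may report more compounds than this note shows. Statements on the series, on what has been measured and on what is new or still open speak of the compounds shown alone.

Measured so far in a functional assay on HeLa cells (Homo sapiens) for inhibition, read by CCK-8 assay, with a stated time of 72 h, tested at 2 uM (on this read-out higher numbers stand for more inhibition of growth at the one concentration tested and lower numbers for less inhibition of growth), are three compounds.
Compound 1 `Cc1cc(C)cc(SCc2ccc(/C=C/C(=O)Nc3ccccc3N)cc2)c1` gives 11.7%
Compound 2 `Nc1ccccc1NC(=O)/C=C/c1ccc(CSc2ccc(Cl)cc2)cc1` gives 1.94%
Compound 3 `CCc1ccc(SCc2ccc(C(=O)Nc3ccccc3N)cc2)cc1` gives 30.8%

Compound 2, at 1.94% in this assay, lies within the scatter of compound 1, and only compound 3 stands clearly higher than it. Compound 4 `Nc1ccccc1NC(=O)/C=C/c1ccc(CSc2ccc(C(F)(F)F)cn2)cc1` has yet to be measured. It carries 5-(trifluoromethyl)pyridin-2-yl in place of 4-chlorophenyl on a sulfur and keeps the rest of compound 2.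

Among the measured compounds shown here, one measured step bears on this change. It sits at the same place, on a sulfur, and a number 9.8 percentage points lower from compound 1 to compound 2 (within the scatter) is a step that stayed within the scatter. Compound 3 differs from compound 2 in more than this group, so its higher value says little about the change. For the measured compounds named here, no measured compound carries the entering group, so the expectation stays loose and is tilted only slightly upward. Expected, then, is a number 5.1 percentage points higher from compound 2 to compound 4 (within the scatter) and nothing beyond the scatter. In this assay the estimated value for compound 4 is 7% with an expected range from 0% to 22% around it.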

Compound 4, percent growth inhibition at one concentration: 6.07%
Estimate against measurement, compound 4: 0.9 percentage points above; the range from low to high includes it.
By their numbers in this assay, from the lowest: compounds 2, 4 and 1 (each within the scatter of the next); then compound 3.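

In this assay, the change from the 4-chlorophenyl to the 5-(trifluoromethyl)pyridin-2-yl on the sulfur gives a number 4.1 percentage points higher from compound 2 to compound 4 (within the scatter) and so does not separate the two groups. Set against the 3,5-dimethylphenyl, the same group gives a number 5.6 percentage points lower from compound 1 to compound 4 (within the scatter) and is not separated from it either. All three groups at this place, including the first with a hetero atom in its ring and a hydrogen-bond acceptor, therefore lie within the scatter of one another on the shared core, and nothing measured here explains this flat result.

On these data alone, whether a group of another kind on the sulfur, such as an amine or a carboxylic acid, would lift the number beyond the scatter stays open. Compound 3 differs from the others in more than one place, so the source of its higher number also stays unresolved.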